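The source may hold more compounds than are shown below. What is called first, only, known or untested is meant among the compounds shown, and "the series" means these compounds.

Compounds measured so far:
compound 1, `CC(C)C[C@@H](NC(=S)Nc1ccccc1)c1nc2ccccc2[nH]1`, 11900 nM;
compound 2, `CC(C)C[C@H](NC(=S)Nc1ccccc1)c1nc2ccccc2[nH]1`, 25800 nM;
compound 3, `CC(C)[C@@H](NC(=S)Nc1cc(C(F)(F)F)cc(C(F)(F)F)c1)c1nc2ccccc2[nH]1`, 16400 nM.

The series was examined in a functional assay on MCF7 cells (Homo sapiens) for cytotoxicity, read by MTT assay; on this read-out higher numbers stand for weaker inhibition and lower numbers for stronger inhibition. Compound 2 gives the highest number of the three, and its nearest neighbour is compound 3; the gap between them lies within the scatter of the assay, so the two cannot be ranked. For the measured compounds named here, the only one-point step is a 2.2-fold higher number from compound 1 to compound 2 (0.34 log units; beyond the scatter), which is modest but beyond the scatter, and it rests on (the fact that compounds 1 and 2 differ only in the configuration as drawn).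

Compound 4, `C[C@H](NC(=S)Nc1ccccc1)c1nc2ccccc2[nH]1`, is the next compound to be measured. It differs from compound 2 by hydrogen in place of isopropyl on a saturated chain carbon, two bonds along the chain from an amide-type nitrogen and an aromatic carbon. Going by the values given here, none of the measured steps touches this part of the molecule: the single measured step concerns configuration alone, and compound 3 differs from compound 2 in more than one place, so its value offers no isolated reading on the side chain. Among the compounds with values here, with no step to lean on, the expectation for compound 4 is a number close to that of compound 2, with a wide range to reflect the uncertainty, and a change of a 1.2-fold higher number from compound 2 to compound 4 (0.07 log units; within the scatter) is anticipated. Compound 4 is therefore estimated at 30000 nM, with a likely range from 10000 nM to 90000 nM.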

Compound 4, half-maximal inhibitory concentration: 196000 nM
Compound 4: the middle estimate sits 6.5-fold (0.82 log units) below what was measured; measured number outside the range, above it.
By their numbers in this assay, from the lowest: compounds 1, 3 and 2 (each within the scatter of the next, the first and the last beyond it); then compound 4.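

In this assay, for the compounds shown here, the side chain at this saturated chain carbon is read on its own for the first time: cutting isobutyl to methyl gives a 7.6-fold higher number from compound 2 to compound 4 (0.88 log units; beyond the scatter), a larger step than the only earlier one, a 2.2-fold higher number from compound 1 to compound 2 (0.34 log units; beyond the scatter), which concerned configuration alone. The chain at this position therefore counts for more in this pair than the drawn configuration did in the earlier pair, and with hydrogen in place of isopropyl, inhibition is weaker, leaving compound 4 with a higher number than any of the three earlier compounds. Nothing on hand accounts for the size of this step.

What the compounds shown leave open is how the number would respond at this carbon to a longer chain such as n-hexyl, to a benzyl or cyclohexylmethyl group, or to an amine or a carboxylic acid carried on the chain. Also open, as far as these compounds go, is whether the opposite configuration of compound 4 would differ from compound 4 as compound 1 differs from compound 2, and whether the same chain change would give a similar step with the trifluoromethyl groups seen in compound 3.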